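Amine swap on the shared core: estimate for compound 3

This account rests on a few compounds, and the source may have more. Where it says the series, first, only, none or still open, it means among the compounds named here.

Compound 1 `CCN1CCN(c2nc(Nc3ccc(C(=O)NC4CC(C)(C)N([O])C(C)(C)C4)cc3)ncc2[N+](=O)[O-])CC1`: 1960 nM
Compound 2 `Cc1cc(Nc2nc(Nc3ccc(C(=O)NC4CC(C)(C)N([O])C(C)(C)C4)cc3)ncc2[N+](=O)[O-])n[nH]1`: 15300 nM

Going by the values given here, in a functional assay on A549 cells (Homo sapiens) for antiproliferative activity, read by MTT assay, with a stated time of 48 h (a lower number here means a stronger inhibitor, a higher number a weaker inhibitor), compound 1 gives 1960 nM, the lower of the two numbers measured so far; compound 2 gives 15300 nM. Among the compounds with values here, the only step that bears on the next change is a 7.8-fold higher number from compound 1 to compound 2 (0.89 log units; beyond the scatter), where a heteroaryl amino group replaced the piperazine. Compound 3 `CCOC(=O)Cc1csc(Nc2nc(Nc3ccc(C(=O)NC4CC(C)(C)N([O])C(C)(C)C4)cc3)ncc2[N+](=O)[O-])n1` makes a change of the same kind: (4-((ethoxycarbonyl)methyl)-1,3-thiazol-2-yl)amino in place of 4-ethylpiperazin-1-yl on an aromatic carbon. A step in the same direction is therefore expected, a 3.1-fold higher number from compound 1 to compound 3 (0.49 log units; beyond the scatter), possibly smaller given the differing ring. Compound 3 is estimated at 6000 nM, with a range from 2000 nM to 20000 nM.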

Compound 3, half-maximal inhibitory concentration: 1040 nM
For compound 3 the middle estimate is 5.8-fold (0.76 log units) above the measured one; the measured number lies below the stated range.
By their numbers in this assay, from the lowest: compounds 3 and 1 (each within the scatter of the next); then compound 2.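

In this assay the change to (4-((ethoxycarbonyl)methyl)-1,3-thiazol-2-yl)amino gives a 1.9-fold lower number from compound 1 to compound 3 (0.28 log units; within the scatter) and so stays within the scatter, which shows that replacing 4-ethylpiperazin-1-yl at this position need not raise the number. Compound 2 goes against any general rule for heteroaryl amino groups here, and the ring on this nitrogen matters, with a 15-fold lower number from compound 2 to compound 3 (1.17 log units; beyond the scatter) as the step between the two. No available evidence explains this difference.

Whether the thiazole ring or its ester-bearing chain accounts for the gap remains open, since the two differ together. A carboxylic acid in place of the ethyl ester, or a plain methyl on the thiazole, would separate them.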